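The source may report more compounds than this note shows. Statements on the series, on what has been measured and on what is new or still open speak of the compounds shown alone.

Working notes on the series. In an ADME assay on L929 cells (Mus musculus) for cytotoxicity, read by resazurin assay, with a stated time of 72 h (on this read-out lower numbers stand for stronger inhibition and higher numbers for weaker inhibition), compound 1 (`O=C(/C=C/c1ccc2c(c1)B(O)OC2)c1ccco1`) gives > 10 ug/mL as a limit and not a number. Compound 2 (`O=C(/C=C/c1ccc2c(c1)B(O)OC2)c1ccccc1`) gives > 10 ug/mL which is also a limit. Compound 3 (`O=C(/C=C/c1ccc2c(c1)B(O)OC2)c1ccc(F)cc1`) gives > 10 ug/mL which is likewise a limit, so it has no numerical place in the series. The data so far amount to the limit of > 10 ug/mL in this assay, at which 3 of the 3 values shown sit, and no order among the three compounds can be read.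

Compound 4 (`O=C(/C=C/c1ccc2c(c1)B(O)OC2)c1ccccc1F`) differs from compound 3 by 2-fluorophenyl in place of 4-fluorophenyl on a carbonyl carbon and it awaits measurement.

The measured steps that bear on this change are a step that the two limits leave unreadable from compound 2 to compound 3 together with a step that the two limits leave unreadable from compound 1 to compound 3 and a step that the two limits leave unreadable from compound 1 to compound 2 and none of them has a readable size. Among the compounds with values here, no measured step moves the fluoro group from one place to another. The expected change is a step that the limit leaves unreadable from compound 3 to compound 4 in this assay and no step beyond the scatter is expected in either direction. This expectation rests on the limit of > 10 ug/mL in this assay, at which 3 of the 3 values shown sit, which compound 3 shares. For compound 4 the estimated value is 20 ug/mL with an expected range from 10 ug/mL to 60 ug/mL and a report of only a limit is the likeliest outcome.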

Compound 4, half-maximal inhibitory concentration: > 10 ug/mL
Compound 4: no number, only a limit (the forecaster's own chance of this, stated with the estimate: 85%); the middle value lies beyond the limit too.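

The steps to compound 4 from compound 1, compound 2 and compound 3 in this assay cannot be read, since all four compounds give only a limit and not a number: the limit of > 10 ug/mL in this assay, at which 4 of the 4 values shown sit. The compounds shown leave open how far each lies beyond that limit, and whether furan-2-yl, phenyl, 4-fluorophenyl or 2-fluorophenyl on the carbonyl carbon makes any difference to the read-out.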